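Benzyl for methyl at the amide of compound 3

This account rests on a few compounds, and the source may have more. Where it says the series, first, only, none or still open, it means among the compounds named here.

Compound 3 `CC(C)c1onc(-c2c(Cl)cccc2Cl)c1COc1ccc(C(=O)N(C)c2cccc(C(=O)O)c2)c(Cl)c1` gives the lowest number of the three in a functional assay on HEK293 cells for agonist activity at Bile acid receptor (Homo sapiens) (on this read-out higher numbers stand for an effect only at larger amounts of compound and lower numbers for an effect already at smaller amounts), at 3100 nM. Compound 1 `CCCNC(=O)c1cccc(/C=C/c2ccc(OCc3c(-c4c(Cl)cccc4Cl)noc3C(C)C)cc2Cl)c1` gives 9000 nM in this assay, and compound 2 `CC(C)c1onc(-c2c(Cl)cccc2Cl)c1COc1ccc(/C=C/c2cccc(C(=O)N(Cc3ccccc3)Cc3ccccc3)c2)c(Cl)c1` gives 35100 nM; both differ from compound 3 in more than one place, so neither isolates a single change. Compound 4 `CC(C)c1onc(-c2c(Cl)cccc2Cl)c1COc1ccc(C(=O)N(Cc2ccccc2)c2cccc(C(=O)O)c2)c(Cl)c1` differs from compound 3 by phenyl in place of hydrogen on a saturated chain carbon bound to an amide-type nitrogen; cut one bond further out, this reads methyl to benzyl. Among the measured compounds shown here, no measured pair shows this change on its own, so the direction rests on nothing firmer than the spread among the three. The expected step, a 1.6-fold higher number from compound 3 to compound 4 (0.21 log units; within the scatter), is small, toward a larger number or none beyond the scatter. Compound 4 is estimated at 5000 nM, with a range from 1500 nM to 20000 nM.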

Compound 4, half-maximal effective concentration: 2500 nM
The estimate for compound 4 lay 2.0-fold (0.30 log units) above the measured number; measured number inside the range.
By their numbers in this assay, from the lowest: compounds 4 and 3 (each within the scatter of the next); then compound 1; then compound 2.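

Methyl to benzyl on the amide-type nitrogen gives a 1.2-fold lower number from compound 3 to compound 4 (0.09 log units; within the scatter), the first reading of this change in the series. This position therefore accepts phenyl on the saturated chain carbon with no shift beyond the scatter, although this rests on one pair in the context of compound 3. Nothing at hand explains this result.

As far as these compounds go, whether the position stays as tolerant with a longer chain ending in an amine remains open. So does whether the same change behaves alike on the cores of compound 1 and compound 2.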